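A few compounds are considered here, and "the series" means these few. Any claim that something is new, unique, unknown or untested is made for them only; others in the source may bear on it.

In a physicochemical assay for solubility (a higher number here means a more soluble compound, a lower number a less soluble compound), compound 1 `COCCN1CC[C@H](C)Nc2cc(ccc2C(N)=O)-n2c(c(C)c3c2CC(C)(C)CC3=O)CC1=O` gives > 100 ug/mL as a limit of the assay and not as a number. Compound 3 `Cc1c2c(n3c1CCCN(CCN)C(=O)[C@H](C)Nc1cc-3ccc1C(N)=O)CC(C)(C)CC2=O` gives > 100 ug/mL as the same limit. Compound 1 therefore stands at the limit of > 100 ug/mL in this assay, at which 2 of the 3 values shown sit, with no exact number. Compound 2 `CC(=O)NCC(=O)N1CCc2c(C)c3c(n2-c2ccc(C(N)=O)c(c2)N[C@@H](C)CC1)CC(C)(C)CC3=O` gives a measured 5 ug/mL in the same test. Compound 4 `Cc1c2c(n3c1CC(=O)N(CCN(C)C)CC[C@H](C)Nc1cc-3ccc1C(N)=O)CC(C)(C)CC2=O` is still unmeasured. It differs from compound 1 by dimethylamino in place of methoxy on a saturated chain carbon, two bonds along the chain from an amide-type nitrogen in a ring with dimethylamino in place of methoxy on a saturated chain carbon, two bonds along the chain from an amide-type nitrogen in a ring. For the measured compounds named here, no measured pair shows this change alone. The estimated step that the limit leaves unreadable from compound 1 to compound 4 is expected to stay within the usual scatter. Compound 4 is estimated at 120 ug/mL with an expected range from 40 ug/mL to 300 ug/mL in this assay when measured.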

Compound 4, solubility: > 100 ug/mL
Compound 4 was reported as a limit; the forecaster's own chance of this, stated with the estimate: 75%; the middle value lies beyond the limit too.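

For the compounds shown here, compound 1 and compound 4 both stand at a limit of the assay, not at a number, so no step between them can be read. From the compounds shown here alone, whether dimethylamino in place of methoxy shifts solubility at all stays open.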